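A few compounds are considered here, and "the series" means these few. Any claim that something is new, unique, unknown or untested is made for them only; others in the source may bear on it.

Compound 1 `O=c1[nH]c(=O)n([C@H]2C[C@H](O)[C@@H](CO)O2)cc1C#CCO`, compound 2 `CCCCCC#Cc1cn([C@H]2C[C@H](O)[C@@H](CO)O2)c(=O)[nH]c1=O` and compound 3 `CC#CCc1cn([C@H]2C[C@H](O)[C@@H](CO)O2)c(=O)[nH]c1=O` share one core and were tested in a functional assay on L1210 cells (Mus musculus); on this read-out lower numbers stand for stronger inhibition and higher numbers for weaker inhibition. Compound 3 sits at a limit of the assay, not at a number, with > 1000 ug/mL. Compound 1 likewise sits at a limit, with > 1000 ug/mL. Compound 2 gives a number, 219 ug/mL. Two of the three values thus rest at a limit (the limit of > 1000 ug/mL in this assay, at which 2 of the 3 values shown sit), and compound 3 stands with compound 1 at the weaker side of what the numbers show; its gap to compound 2 is read as an at least 4.5-fold higher number from compound 2 to compound 3 (0.65 log units; beyond the scatter). Compound 4 `CCC#Cc1cn([C@H]2C[C@H](O)[C@@H](CO)O2)c(=O)[nH]c1=O` is the next step: but-1-yn-1-yl in place of but-2-yn-1-yl on an aromatic carbon. The measured step that bears on it most directly is the one with but-2-yn-1-yl in place of hept-1-yn-1-yl, an at least 4.5-fold higher number from compound 2 to compound 3 (0.65 log units; beyond the scatter), taken here in the opposite sense but with a shorter chain. In the step of an at least 4.5-fold lower number from compound 1 to compound 2 (0.65 log units; beyond the scatter) butyl replaced hydroxy on a saturated chain carbon bound to a triple-bonded carbon and the number fell; compound 4 carries no hydroxy on its chain. In this assay compound 4 is therefore expected to give a number near 500 ug/mL, in the range 150 ug/mL to 1500 ug/mL. The expected step is an at least 2.0-fold lower number from compound 3 to compound 4 (0.30 log units; that floor lies within the scatter).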

Compound 4, concentration for 50% inhibition: > 1000 ug/mL
Compound 4 was reported as a limit; the forecaster's own chance of this, stated with the estimate: 45%; middle value at least 2.0-fold (0.30 log units) away from the limit.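

With no hydroxy on the chain, the shorter but-1-yn-1-yl group still falls short of hept-1-yn-1-yl in this assay, so removing the hydroxy is not enough on its own at this aromatic carbon: an at least 4.5-fold higher number from compound 2 to compound 4 (0.65 log units; beyond the scatter). Shifting the triple bond from but-2-yn-1-yl to but-1-yn-1-yl brings no readable change, and the steps to compound 4 from compound 3 and from compound 1 cannot be read, since both values in each pair are limits. Among the compounds shown, only hept-1-yn-1-yl gives a number rather than a limit: the limit of > 1000 ug/mL in this assay, at which 3 of the 4 values shown sit.

From the compounds shown here alone, whether the number falls gradually with chain length remains open, and a pent-1-yn-1-yl or hex-1-yn-1-yl group would address this. Also open, going by these compounds, are a longer chain such as non-1-yn-1-yl and an amine or carboxylic acid at the chain end.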